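Cyclohexyl Isomers and a Shared Solubility Limit

A few compounds are considered here, and "the series" means these few. Any claim that something is new, unique, unknown or untested is made for them only; others in the source may bear on it.

Measured so far in a physicochemical assay for solubility, measured as thermodynamic solubility, with a stated time of 24 h, at pH 6.8; a higher number here means a more soluble compound, a lower number a less soluble compound:
Compound 1 `C[C@H]1CCCC[C@H]1NC(=O)c1cc2c(Cl)cc(Cl)cc2[nH]1` gives < 4000 nM, which is a limit of the assay and not a number.
Compound 2 `CC1CCC(NC(=O)c2cc3c(Cl)cc(Cl)cc3[nH]2)CC1` gives < 4000 nM, likewise a limit.
Compound 3 `C[C@H]1CCCC[C@H]1NC(=O)c1cc2c(F)cc(F)cc2[nH]1` gives < 4000 nM, again a limit.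

Compound 4 `CC1CCC(NC(=O)c2cc3c(F)cc(F)cc3[nH]2)CC1` has not yet been measured in this assay. It stands to compound 3 exactly as compound 2 stands to compound 1: the change 4-methylcyclohexyl in place of 2-methylcyclohexyl on an amide-type nitrogen and the change 4-methylcyclohexyl in place of 2-methylcyclohexyl on an amide-type nitrogen are the same change, made at the same place on the amide-type nitrogen. Compound 1 and compound 3 carry different cores, but the difference between the two cores is not broken down here. The measured step that the two limits leave unreadable from compound 1 to compound 2 has no readable size, as both of its ends are limits. What can be expected for compound 4 rests on (the limit of < 4000 nM in this assay, at which 3 of the 3 values shown sit), with three of three values sitting there. The step that the limit leaves unreadable from compound 3 to compound 4 is therefore expected to be unreadable as well, because the limit of < 4000 nM in this assay, at which 3 of the 3 values shown sit, is where compound 3 already sits. Compound 4 is expected to give about 2000 nM, with a plausible range from 400 nM to 4000 nM, and most likely to be reported only as a limit.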

Compound 4, solubility: < 4000 nM
Compound 4 gave a limit, no number; the forecaster's own chance of this, stated with the estimate: 85%; the middle value does not contradict the limit.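

In this assay, compound 3 and compound 4 both give a limit and not a number, so the step between them cannot be read, because all the compounds shown sit at the same limit: the limit of < 4000 nM in this assay, at which 4 of the 4 values shown sit. The compounds shown leave open whether 4-methylcyclohexyl in place of 2-methylcyclohexyl, or the difference between the two cores, changes solubility at all.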